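Removing the cyclopropyl group from compound 2

This account rests on a few compounds, and the source may have more. Where it says the series, first, only, none or still open, it means among the compounds named here.

Values in a functional assay on BXPC-3 cells (Homo sapiens) for cytotoxicity, read by MTT assay, with a stated time of 72 h; on this read-out higher numbers stand for weaker inhibition and lower numbers for stronger inhibition:
- Compound 1 `CC(C)c1[nH]cnc1/C=c1\[nH]c(=O)/c(=C/c2cccc(C(=O)c3ccc(F)cc3)c2)[nH]c1=O`: 0.6 nM
- Compound 2 `O=C(c1ccc(F)cc1)c1cccc(/C=c2\[nH]c(=O)/c(=C/c3nc[nH]c3C3CC3)[nH]c2=O)c1`: 1.4 nM
- Compound 3 `O=C(c1ccc(F)cc1)c1cccc(/C=c2\[nH]c(=O)/c(=C/c3c[nH]cn3)[nH]c2=O)c1`: not yet measured

For the measured compounds named here, of the two measured compounds, compound 2 has the higher number at 1.4 nM, and compound 1 is its only neighbour. The next change leads to compound 3: hydrogen in place of cyclopropyl on an aromatic carbon. In words, this is hydrogen in place of cyclopropyl on an aromatic carbon.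

Going by the values given here, only one measured step bears on this change: a 2.3-fold higher number from compound 1 to compound 2 (0.37 log units; beyond the scatter). That step is modest, and it exchanged one group for another at the same carbon. Neither measured compound has hydrogen there, so the data give no direct reading of what losing the group does. Removing the group outright is a larger structural change than the swap behind a 2.3-fold higher number from compound 1 to compound 2 (0.37 log units; beyond the scatter), so a larger step towards a higher number in this assay is expected, though with wide uncertainty. The expected change is an 8.6-fold higher number from compound 2 to compound 3 (0.93 log units; beyond the scatter). The estimate for compound 3 is 12 nM, with an expected range of 2.5 nM to 60 nM.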

Compound 3, half-maximal inhibitory concentration: 4.3 nM
Compound 3: middle estimate off by 2.8-fold (0.45 log units), on the high side; measured number inside the range.
By their numbers in this assay, from the lowest: compound 1; then compound 2; then compound 3.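

In this assay, for the compounds shown here, compound 3 gives the first reading of this imidazole carbon with hydrogen on it, and the loss of cyclopropyl comes to a 3.1-fold higher number from compound 2 to compound 3 (0.49 log units; beyond the scatter) while the loss of isopropyl comes to a 7.2-fold higher number from compound 1 to compound 3 (0.86 log units; beyond the scatter) on the same carbon. Both steps lie beyond the scatter and both are modest, so either alkyl group gives a lower number than hydrogen here, yet a substituent at this place is not required for activity, as compound 3 still reads 4.3 nM in this cell assay. Nothing at hand explains why hydrogen gives the highest number of the three or why isopropyl gives a lower one than cyclopropyl.

The compounds shown leave open how a methyl group, a longer chain, an amine or a carboxylic acid on this carbon would read against hydrogen and the two alkyl groups. They also leave open whether the same order of isopropyl, cyclopropyl and hydrogen would hold if another part of the molecule were changed.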